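The compounds below may be only part of what the source reports. "The series", "measured", "known", "first", "only" and "open" are said of these compounds alone.

Measured in an assay for inhibition of 6-phosphofructo-2-kinase/fructose-2,6-bisphosphatase 3 (Homo sapiens), read by ADP-Glo, with a stated time of 2 h; on this read-out higher numbers stand for weaker inhibition and lower numbers for stronger inhibition:
compound 1 `CN1CCC(CNS(=O)(=O)c2ccccc2Nc2cc(-c3ccc4ccn(C)c4c3)c3nccnc3c2)C1`: 11 nM
compound 2 `CNS(=O)(=O)c1ccccc1Nc1cc(-c2ccc3ccn(C)c3c2)c2nccnc2c1`: 104 nM
compound 3 `Cn1ccc2ccc(-c3cc(Nc4ccccc4S(=O)(=O)N4CCOCC4)cc4nccnc34)cc21`: 36 nM

Compound 3 stands second highest of the three numbers in this assay: a 3.3-fold higher number from compound 1 to compound 3 (0.51 log units; beyond the scatter) and a 2.9-fold lower number from compound 2 to compound 3 (0.46 log units; beyond the scatter) place it between the other two. Compound 4 `Cn1ccc2ccc(-c3cc(Nc4ccccc4S(=O)(=O)NCC4CCOCC4)cc4nccnc34)cc21` differs from compound 3 by ((oxan-4-yl)methyl)amino in place of morpholin-4-yl on a sulfonyl sulfur. Among the measured compounds shown here, two measured steps bear on this. The step of a 2.9-fold lower number from compound 2 to compound 3 (0.46 log units; beyond the scatter) shows that a ring on the sulfonyl sulfur gave a lower number than a plain methylamino, and the step of a 3.3-fold higher number from compound 1 to compound 3 (0.51 log units; beyond the scatter) shows that a ring carried on a methylamino gave a lower number still than morpholin-4-yl. Compound 4 carries a ring on a methylamino, as compound 1 does, so a modest lowering is expected, a 1.8-fold lower number from compound 3 to compound 4 (0.26 log units; within the scatter). The estimate for compound 4 in this assay is 20 nM, ranging from 7 nM to 60 nM.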

Compound 4, half-maximal inhibitory concentration: 26 nM
The estimate for compound 4 lay 1.3-fold (0.11 log units) below the measured number; low and high end bracket the measured number.
By their numbers in this assay, from the lowest: compound 1; then compounds 4 and 3 (each within the scatter of the next); then compound 2.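

In this assay the step on the sulfonyl sulfur is a 1.4-fold lower number from compound 3 to compound 4 (0.14 log units; within the scatter) and so does not separate ((oxan-4-yl)methyl)amino from morpholin-4-yl, even though the entering group adds a hydrogen-bond donor. On the saturated chain carbon, oxan-4-yl in place of hydrogen gives a 4.0-fold lower number from compound 2 to compound 4 (0.60 log units; beyond the scatter) while oxan-4-yl in place of 1-methylpyrrolidin-3-yl gives a 2.4-fold higher number from compound 1 to compound 4 (0.37 log units; beyond the scatter) so that a ring there helps without matching compound 1. No evidence is at hand to explain these steps. Open remains whether the ring nitrogen of compound 1 matters, which a piperidin-4-yl or an open-chain dimethylamino group on that carbon could test.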